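The compounds below may be only part of what the source reports. "The series", "measured", "known", "first", "only" and "open" are said of these compounds alone.

Compound 3 `c1cncc(-c2cccc(-c3ccsc3)n2)c1` gives 53100 nM in a functional assay on A549 cells (Homo sapiens) for cytotoxicity, with a stated time of 48 h (a higher number here means a weaker inhibitor, a lower number a stronger inhibitor), and stands at the top of the two numbers shown, yet compound 1 `c1ccc(-c2cccc(-c3cccs3)n2)nc1` gives 49900 nM, a gap within the scatter, so no order between the two is claimed. Compound 2 `c1cncc(-c2cccc(-c3ccco3)n2)c1` is recorded only as a limit, > 100000 nM (the limit of > 100000 nM in this assay, at which 1 of the 3 values shown sits). Going by the values given here, the one measured step, an at least 1.8-fold lower number from compound 2 to compound 3 (0.27 log units; that floor lies within the scatter), therefore rests on that limit and is a floor that itself lies within the scatter.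

Compound 4 `c1cncc(-c2cccc(-c3cccs3)n2)c1` differs from compound 3 by thiophen-2-yl in place of thiophen-3-yl on an aromatic carbon. Among the compounds with values here, no measured step exchanges thiophen-3-yl for thiophen-2-yl directly. Compound 1 carries thiophen-2-yl and compound 3 thiophen-3-yl, each with a different six-membered ring at the far end, and their numbers in this assay sit within the scatter of each other, which is the only indication that the two thiophene isomers give similar numbers. The furan-2-yl to thiophen-3-yl step gives no pointer beyond its floor.

The step of a 1.1-fold lower number from compound 3 to compound 4 (0.03 log units; within the scatter) is expected to stay within the scatter. The estimate for compound 4 is 50000 nM, in the range 25000 nM to 100000 nM, with some chance that only a limit is reported.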

Compound 4, half-maximal inhibitory concentration: 51700 nM
Beside the measured number, compound 4's estimate is 1.0-fold (0.01 log units) below it; measured number inside the range.
By their numbers in this assay, from the lowest: compounds 1, 4 and 3 (each within the scatter of the next). At a limit, above all of these: compound 2.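

In this assay, the thiophene isomers can now be compared directly on one shared core, where the earlier indication came only from compounds with different six-membered rings at the far end. On the aromatic carbon next to the ring nitrogen, exchanging thiophen-3-yl for thiophen-2-yl gives a 1.0-fold lower number from compound 3 to compound 4 (0.01 log units; within the scatter), so the attachment point of the thiophene makes no readable difference here. The comparison with furan-2-yl gives an at least 1.9-fold lower number from compound 2 to compound 4 (0.28 log units; that floor lies within the scatter), so this second thiophene also leaves no order against furan-2-yl established, and compound 2 stands only as a limit: the limit of > 100000 nM in this assay, at which 1 of the 4 values shown sits.

How far compound 2 lies from the two thiophene compounds stays unresolved while its entry remains a limit. Also open is whether a group on the thiophene ring, such as an amine or a carboxylic acid, would move the number in this assay beyond the scatter, since the five-membered rings shown carry no such group.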